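Swapping cyclopropyl for chloro on a phenol ring

This account rests on a few compounds, and the source may have more. Where it says the series, first, only, none or still open, it means among the compounds named here.

Compound 1, `N#Cc1cc(C(=O)N2CCc3ccccc32)cc(I)c1O`: 5300 nM in an assay on tissue (RPTEC cells) for inhibition of solute carrier family 22 member 12 (Homo sapiens), read by scintillation counting, with stated times of 15 min and 2 h; on this read-out higher numbers stand for weaker inhibition and lower numbers for stronger inhibition
Compound 2, `N#Cc1cc(C(=O)N2CCc3ccccc32)cc(C2CC2)c1O`: 8800 nM in this assay

Both compounds share one core and differ only in a single group on the aromatic ring that carries the hydroxy and the cyano groups. Compound 2 stands at one end of the two numbers, with compound 1 nearest: a 1.7-fold higher number from compound 1 to compound 2 (0.22 log units; within the scatter) is a gap within the usual scatter, so the two compounds cannot be told apart on these numbers.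

The next compound is compound 3, `N#Cc1cc(C(=O)N2CCc3ccccc32)cc(Cl)c1O`. Its change from compound 2 is chloro in place of cyclopropyl on an aromatic carbon. Among the measured compounds shown here, the only measured step that bears on this is the one from compound 1 to compound 2, which also exchanged a halogen for cyclopropyl at the same place, in the opposite direction, and gave a 1.7-fold higher number from compound 1 to compound 2 (0.22 log units; within the scatter). Since that exchange stayed within the scatter, no step beyond the scatter is expected here either, though a somewhat lower number would be in line with compound 1.

For compound 3 the expected value in this assay is 6000 nM, with a likely range from 2500 nM to 15000 nM. This estimate corresponds to a step of a 1.5-fold lower number from compound 2 to compound 3 (0.17 log units; within the scatter).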

Compound 3, half-maximal inhibitory concentration: 14700 nM
Beside the measured number, compound 3's estimate is 2.5-fold (0.39 log units) below it; the measured number falls inside the stated range.
By their numbers in this assay, from the lowest: compounds 1, 2 and 3 (each within the scatter of the next, the first and the last beyond it).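

At this place on the ring, ortho to a hydroxy group, exchanging cyclopropyl for chloro does not separate the two compounds in this assay, with a 1.7-fold higher number from compound 2 to compound 3 (0.22 log units; within the scatter), so compound 2 remains within the scatter of both halogen-bearing compounds and its rank among the three stays unsettled. The new information comes from comparing the two halogens: chloro in place of iodo gives a 2.8-fold higher number from compound 1 to compound 3 (0.44 log units; beyond the scatter), a modest step but the first in this short series to pass the scatter, which shows that the reading can respond to a single-atom exchange at this place. No measurement is available to explain this difference.

The compounds shown leave open how bromo or fluoro would read at this place, and so whether iodo and chloro are part of a wider trend among the halogens or only an isolated pair. They also leave open whether a different kind of group here, such as an amine or a carboxylic acid, would move the number further in either direction, and whether the step from iodo to chloro would hold on another core.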